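Chalcone series: para nitro for chloro on compound 1

This account rests on a few compounds, and the source may have more. Where it says the series, first, only, none or still open, it means among the compounds named here.

Compound 1 `COc1cc(OC)c(C(=O)/C=C/c2ccc(Cl)cc2)c(OC)c1` is the starting point of this step. Within the data shown here, in a functional assay on MDA-MB-231 cells (Homo sapiens) for cytotoxicity, with a stated time of 48 h (a higher number here means a weaker inhibitor, a lower number a stronger inhibitor), compound 1 gives 8200 nM, the lowest of the three numbers so far, though its gaps to the others fall within the scatter. Compound 3 `COc1cc(OC)c(C(=O)/C=C/c2ccccc2SC)c(OC)c1` gives 9900 nM in this assay, and compound 2 `COc1cccc(/C=C/C(=O)c2c(O)cc(OC)cc2OC)c1` gives 13200 nM. Among the measured compounds shown here, the one step between measured compounds that differ in a single place, a 1.2-fold higher number from compound 1 to compound 3 (0.08 log units; within the scatter), is within the scatter.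

Compound 4 `COc1cc(OC)c(C(=O)/C=C/c2ccc([N+](=O)[O-])cc2)c(OC)c1` is not yet measured. It differs from compound 1 as follows: nitro in place of chloro on an aromatic carbon. For the measured compounds named here, no measured step exchanges chloro for nitro, so the only direct bearing comes from the step from compound 1 to compound 3, which swaps one substituent on the same ring for another and stays within the scatter; the spread across all three measured compounds is also within the scatter. On that basis no step beyond the scatter is expected from compound 1 to compound 4, in either direction.

Compound 4 is therefore estimated at 9000 nM in this assay, with a range of 3000 nM to 27000 nM, meaning an expected step of a 1.1-fold higher number from compound 1 to compound 4 (0.04 log units; within the scatter).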

Compound 4, half-maximal inhibitory concentration: 3300 nM
Compound 4: the middle estimate sits 2.7-fold (0.44 log units) above what was measured, and the stated range covers the measured number.
By their numbers in this assay, from the lowest: compound 4; then compounds 1, 3 and 2 (each within the scatter of the next).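

At this aromatic carbon, para to a large group, nitro in place of chloro gives a 2.5-fold lower number from compound 1 to compound 4 (0.40 log units; beyond the scatter) in this assay, the only step among the compounds shown that lies beyond the scatter. The earlier step, a 1.2-fold higher number from compound 1 to compound 3 (0.08 log units; within the scatter), changed the group and where it sits on the ring at once and stayed within the scatter, so it gave no sign that this ring could move the number; the new step shows that the group at this one position can, at least for this pair. The entering nitro has more heavy atoms than chloro and, unlike chloro, counts as a hydrogen-bond acceptor, but a single pair cannot show whether either difference matters, and no measurement accompanying the series accounts for the step.

As far as these compounds go, whether the lower number is particular to nitro or would also appear with a nitrile, a methyl ester or an amine on the same aromatic carbon stays open. Also open, from the compounds shown here alone, is how a plain hydrogen at this position compares with chloro and nitro on the core of compound 1.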